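Chloro for methyl on the aryl ring of compound 1

A few compounds are considered here, and "the series" means these few. Any claim that something is new, unique, unknown or untested is made for them only; others in the source may bear on it.

Compound 1 `COC(=O)C1(c2ccc(C)cc2)CC1CN1CCC(Cc2ccccc2)CC1` gives 0.97 nM in an assay for displacement of a labelled ligand from Sigma non-opioid intracellular receptor 1 (Cavia porcellus) (on this read-out lower numbers stand for stronger inhibition and higher numbers for weaker inhibition), the lowest of the two numbers here. Compound 3 `COC(=O)C1(c2ccc(C)cc2)CC1CN1CCN(c2ccccn2)CC1` gives 497 nM in this assay, a gap from compound 1 beyond the scatter. Compound 2 `COC(=O)C1(c2ccc(N)cc2)CC1CN1CCN(c2ncccn2)CC1` returns only a limit, > 10000 nM, which is the limit of > 10000 nM in this assay, at which 1 of the 3 values shown sits. Compound 4 `COC(=O)C1(c2ccc(Cl)cc2)CC1CN1CCC(Cc2ccccc2)CC1` differs from compound 1 only by chloro in place of methyl on an aromatic carbon, with the rest of the shared core unchanged. For the measured compounds named here, no measured pair isolates this swap, and the two substituents are matched in size and in counted donors and acceptors, so the step of a 1.5-fold higher number from compound 1 to compound 4 (0.19 log units; within the scatter) is expected to be small, in either direction, and likely within the scatter. Compound 4 is therefore estimated at 1.5 nM in this assay, with a range of 0.4 nM to 6 nM.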

Compound 4, inhibition constant: 0.82 nM
Compound 4: the middle estimate sits 1.8-fold (0.26 log units) above what was measured, within the range that was stated.
By their numbers in this assay, from the lowest: compounds 4 and 1 (each within the scatter of the next); then compound 3. At a limit, above all of these: compound 2.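

The change from 4-methylphenyl to 4-chlorophenyl gives a 1.2-fold lower number from compound 1 to compound 4 (0.07 log units; within the scatter), so in this assay methyl and chloro at this position cannot be told apart on this core. The earlier compounds shown here offered no pair that isolated this position. Nothing measured here bears on why the two groups read alike.

On these data alone, how a methoxy group or a longer chain such as butyl would read at this position stays open. So does whether chloro and methyl also read alike on the core of compound 3.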